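Compound 3 to compound 4: smaller sulfonamide substituent

The compounds below may be only part of what the source reports. "The series", "measured", "known", "first", "only" and "open" are said of these compounds alone.

Measured in an in vitro ADME assay on microsomes from liver (Homo sapiens) for metabolic stability, read by LC-MS, tested at 1 uM; a higher number here means faster removal of the compound, a lower number slower removal:
- compound 1 `CCCS(=O)(=O)c1cccc(C#Cc2cc(Cl)ccc2OCC(=O)O)c1`: 11 mL.min-1.g-1
- compound 2 `O=C(O)COc1ccc(Cl)cc1C#Cc1ccc(CO)cc1F`: < 10 mL.min-1.g-1
- compound 3 `Cc1ccc(S(=O)(=O)N(C)C(C)C)cc1C#Cc1cc(Cl)ccc1OCC(=O)O`: < 10 mL.min-1.g-1

Compound 3 gives < 10 mL.min-1.g-1, which is a limit of the assay and not a number. Compound 2 gives < 10 mL.min-1.g-1, which is also a limit. Among the measured compounds shown here, compound 1 gives 11 mL.min-1.g-1, the only true number so far. The series therefore stands largely at the limit of < 10 mL.min-1.g-1 in this assay, at which 2 of the 3 values shown sit, and compound 3 cannot be placed more exactly within it.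

The next compound is compound 4 `Cc1ccc(S(=O)(=O)N(C)C)cc1C#Cc1cc(Cl)ccc1OCC(=O)O`, which carries methyl in place of isopropyl on a sulfonamide nitrogen. For the measured compounds named here, no two measured compounds differ in one place only, so the series offers no measured precedent for this change. No step beyond the usual scatter is expected in this assay, and no direction can be assigned with confidence. The expectation rests on compound 3 at < 10 mL.min-1.g-1, a limit, so it is weakly anchored. The expected change is a step that the limit leaves unreadable from compound 3 to compound 4, and it is not expected to exceed the scatter. Another report of a limit is the likeliest outcome. The estimate for compound 4 is 7 mL.min-1.g-1, with an expected range of 4 mL.min-1.g-1 to 12 mL.min-1.g-1.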

Compound 4, intrinsic clearance in microsomes: < 10 mL.min-1.g-1
Compound 4 was reported as a limit; the forecaster's own chance of this, stated with the estimate: 70%; the middle value is on the limit's open side.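

In this assay compound 4 gives < 10 mL.min-1.g-1, which is a limit of the assay. Compound 3 also stands at a limit, so no step can be read between compound 3 and compound 4. The compounds shown leave open whether methyl in place of isopropyl on a sulfonamide nitrogen changes the clearance at all, since the series stands at: the limit of < 10 mL.min-1.g-1 in this assay, at which 3 of the 4 values shown sit.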